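The source may hold more compounds than are shown below. What is called first, only, known or untested is meant among the compounds shown, and "the series" means these compounds.

In a functional assay on B16-F0 cells (Mus musculus) for inhibition, read by CCK-8 assay, with a stated time of 48 h (a lower number here means a stronger inhibitor, a higher number a weaker inhibitor), compound 1 `COc1cc(-c2cc3nccc(-c4cc(OC)c(OC)c(OC)c4)n3n2)cc(OC)c1OC` reaches only a limit of > 10000 nM and gives no number. Compound 2 `COc1cc(-c2ccnc3cc(-c4ccc(F)cc4)nn23)cc(OC)c1OC` gives 4540 nM in this assay and compound 3 `COc1cc(-c2ccnc3cc(-c4cn(CO)c5ccccc45)nn23)cc(OC)c1OC` gives 93 nM as the lower of the two numbers. Among the compounds with values here, compound 3 therefore stands at the low end of the series so far, with compound 2 as its nearest neighbour and well above it.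

Compound 4 `COc1cc(-c2ccnc3cc(-c4c[nH]c5ccccc45)nn23)cc(OC)c1OC` has hydrogen in place of hydroxymethyl on an aromatic nitrogen of a five-membered aromatic ring that is part of a fused or bridged system of two rings. Within the data shown here, no measured pair isolates a change of this kind, so the expectation rests on compound 3 at 93 nM alone. The ring system stays and only the hydroxymethyl goes, so a small step in this assay is expected, not beyond the scatter and leaning slightly towards a lower number. From the compounds shown here alone, the estimated step is a 1.6-fold lower number from compound 3 to compound 4 (0.19 log units; within the scatter) and either direction remains open. The expected value for compound 4 is 60 nM with an estimated range of 15 nM to 300 nM.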

Compound 4, half-maximal inhibitory concentration: 40 nM
Beside the measured number, compound 4's estimate is 1.5-fold (0.18 log units) above it, within the range that was stated.
By their numbers in this assay, from the lowest: compound 4; then compound 3; then compound 2. At a limit, above all of these: compound 1.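

Hydrogen in place of hydroxymethyl on an aromatic nitrogen gives a 2.3-fold lower number from compound 3 to compound 4 (0.37 log units; beyond the scatter) in this assay, so the hydroxymethyl group is not required for activity in this pair, and the number at this position responds to the change. 1H-indol-3-yl in place of 4-fluorophenyl on an aromatic carbon gives a 110-fold lower number from compound 2 to compound 4 (2.05 log units; beyond the scatter), a far larger step than the one at the nitrogen. No measured property in hand bears on why either step occurs.

From the compounds shown here alone, whether a methyl group, an acetyl group or a longer chain ending in an amine on this nitrogen would fall nearer compound 3 or compound 4 stays open. Also open, going by these compounds, is how a methoxy group or a nitrile on the 1H-indol-3-yl group would move the number.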